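The compounds below may be only part of what the source reports. "The series", "measured", "known", "first", "only" and "open" are said of these compounds alone.

Compound 1 `COc1ccc(C(=O)/C=C/c2ccc(-n3cc(CSc4nnc(-c5ccccc5)c(-c5ccccc5)n4)nn3)cc2)cc1` and compound 2 `O=c1ccc2ccc(OCCCn3cc(CSc4nnc(-c5ccccc5)c(-c5ccccc5)n4)nn3)cc2o1` share a common core and both sit at the edge of what a functional assay on ECa-109 cells for antiproliferative activity against ECa-109 cell line (Homo sapiens), read by MTT assay, with a stated time of 48 h (a higher number here means a weaker inhibitor, a lower number a stronger inhibitor), can report. In this assay compound 1 gives only a limit, > 100000 nM. In this assay compound 2 likewise gives only a limit, > 100000 nM, so that the limit of > 100000 nM in this assay, at which 2 of the 2 values shown sit, describes everything known so far. Compound 3 `O=c1cc(OCCCn2cc(CSc3nnc(-c4ccccc4)c(-c4ccccc4)n3)nn2)c2ccccc2o1` is built from the same atoms as compound 2, joined differently: a group of 11 heavy atoms (9 carbon, 2 oxygen; one six-membered aromatic ring of carbon only, one six-membered aromatic ring with 1 hetero atom) in place of a group of 11 heavy atoms (9 carbon, 2 oxygen; one six-membered aromatic ring of carbon only, one six-membered aromatic ring with 1 hetero atom), on an oxygen on a saturated carbon. Among the compounds with values here, with no measured step to lean on, the change is expected to bring no shift beyond the scatter, so the step that the limit leaves unreadable from compound 2 to compound 3 is estimated as flat. Compound 3 is therefore expected to give 150000 nM, within 40000 nM to 600000 nM.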

Compound 3, half-maximal inhibitory concentration: > 100000 nM
Compound 3 gave a limit, no number; the forecaster's own chance of this, stated with the estimate: 80%; the middle value lies beyond the limit too.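

Within the data shown here, compound 3, like compound 2, gives only a limit in this assay, so no step between compound 2 and compound 3 can be read: the limit of > 100000 nM in this assay, at which 3 of the 3 values shown sit. The compounds shown leave open how they rank against one another in this assay.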